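Pyridin-2-yl to thiophen-2-yl: compound 3 to compound 4

This account rests on a few compounds, and the source may have more. Where it says the series, first, only, none or still open, it means among the compounds named here.

Measured in a functional assay on HCT-116 cells (Homo sapiens) for antiproliferative activity, read by MTT assay, with a stated time of 24 h; on this read-out lower numbers stand for stronger inhibition and higher numbers for weaker inhibition:
compound 1 `COc1ccc(C(=O)/C=C/c2ccc(F)cc2)c2c1C=CC(C)(C)O2` — > 10000 nM, a limit of the assay
compound 2 `COc1ccc(C(=O)/C=C/c2ccc([N+](=O)[O-])cc2)c2c1C=CC(C)(C)O2` — 8880 nM
compound 3 `COc1ccc(C(=O)/C=C/c2ccccn2)c2c1C=CC(C)(C)O2` — 6630 nM

Compound 3 and compound 2 sit within the scatter of one another, a 1.3-fold lower number from compound 2 to compound 3 (0.13 log units; within the scatter). Compound 1 reaches only a limit of > 10000 nM in this assay, at which 1 of the 3 values shown sits, in this assay, so the steps of an at least 1.1-fold lower number from compound 1 to compound 2 (0.05 log units; that floor lies within the scatter) and an at least 1.5-fold lower number from compound 1 to compound 3 (0.17 log units; that floor lies within the scatter) are floors and remain small.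

Compound 4 `COc1ccc(C(=O)/C=C/c2cccs2)c2c1C=CC(C)(C)O2` is not yet measured. It differs from compound 3 by thiophen-2-yl in place of pyridin-2-yl on a double-bonded chain carbon bound to a double-bonded chain carbon. The two steps that bear on this place, an at least 1.5-fold lower number from compound 1 to compound 3 (0.17 log units; that floor lies within the scatter) and a 1.3-fold lower number from compound 2 to compound 3 (0.13 log units; within the scatter), each exchange the ring on the double-bonded chain carbon, and neither moves the number beyond the scatter. Three rings in that position give numbers close together, so no step beyond the scatter is expected in this assay from compound 3 to compound 4, a 1.0-fold lower number from compound 3 to compound 4 (0.01 log units; within the scatter). Compound 4 is therefore estimated at 6500 nM, with a range from 2500 nM to 16000 nM.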

Compound 4, half-maximal inhibitory concentration: > 10000 nM
Compound 4: a limit, no number (the forecaster's own chance of this, stated with the estimate: 25%); middle value at least 1.5-fold (0.18 log units) from the limit.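

In this assay compound 4 gives > 10000 nM, a limit of the assay and not a number. The readable steps, an at least 1.5-fold higher number from compound 3 to compound 4 (0.17 log units; that floor lies within the scatter) and an at least 1.1-fold higher number from compound 2 to compound 4 (0.05 log units; that floor lies within the scatter), are floors only, so thiophen-2-yl on this double-bonded chain carbon shows no step beyond the scatter, and the step between compound 1 and compound 4 cannot be read. With a five-membered aromatic ring now added to the six-membered ones, a second ring at this place stands at the limit: the limit of > 10000 nM in this assay, at which 2 of the 4 values shown sit.

As far as these compounds go, how far compound 1 and compound 4 really lie from compound 2 and compound 3 remains open. Also open, from the compounds shown here alone, is whether an amine or a carboxylic acid on this ring, or a longer chain in its place, would move the number in this assay beyond the scatter.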